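The source may report more compounds than this note shows. Statements on the series, on what has been measured and on what is new or still open speak of the compounds shown alone.

In a functional assay on PC-12 cells (Rattus norvegicus) for cytotoxicity, read by MTT assay, with stated times of 2 h and 24 h, tested at 5 uM (a lower number here means a weaker effect, a higher number a stronger effect of the compound at the concentration tested), compound 3 `Oc1cc(C(F)(F)F)ccc1-c1nc(-c2ccccc2O)n(-c2ccc(C(F)(F)F)cc2)n1` gives 90.5%. The other two measured compounds carry a different group at the same place: compound 1 `Oc1cc(C(F)(F)F)ccc1-c1nc(-c2ccccc2O)n(-c2ccc(Cl)cc2)n1` gives 87.3% and compound 2 `Oc1cc(C(F)(F)F)ccc1-c1nc(-c2ccccc2O)n(-c2ccc(I)cc2)n1` gives 94.4%, so all three numbers sit close together, as shown by a number 3.2 percentage points higher from compound 1 to compound 3 (within the scatter) and a number 3.9 percentage points lower from compound 2 to compound 3 (within the scatter). Compound 4 `Oc1cc(C(F)(F)F)ccc1-c1nc(-c2ccccc2O)n(-c2ccc(OC(F)(F)F)cc2)n1` differs from compound 3 by trifluoromethoxy in place of trifluoromethyl on an aromatic carbon. Among the measured compounds shown here, no measured step involves trifluoromethoxy; the steps at this position, a number 7.1 percentage points higher from compound 1 to compound 2 (within the scatter), a number 3.2 percentage points higher from compound 1 to compound 3 (within the scatter) and a number 3.9 percentage points lower from compound 2 to compound 3 (within the scatter), all stay within the scatter, so for compound 4 an expected step of a number 0.5 percentage points lower from compound 3 to compound 4 (within the scatter) in this assay seems reasonable, none beyond the scatter. Compound 4 is therefore estimated at 90%, with a range from 82% to 97%.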

Compound 4, a percentage reported as activity, at one concentration (the size of the read-out at that concentration, not a potency): 84.9%
The estimate for compound 4 lay 5.1 percentage points above the measured number; low and high end bracket the measured number.
By their numbers in this assay, from the lowest: compounds 4, 1, 3 and 2 (each within the scatter of the next).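

In this assay, trifluoromethoxy on this aromatic carbon, para to a large group, does not separate from any of the three groups tested before it, with a number 5.6 percentage points lower from compound 3 to compound 4 (within the scatter) and a number 9.5 percentage points lower from compound 2 to compound 4 (within the scatter) and a number 2.4 percentage points lower from compound 1 to compound 4 (within the scatter). The added oxygen of trifluoromethoxy thus leaves the read-out within the scatter of trifluoromethyl, and the position stays flat across all four groups. Nothing available explains these small steps. On these data alone, whether an amine or a carboxylic acid at this place would step beyond the scatter remains open. So does whether the two hydroxyl groups on the shared core matter to the read-out.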